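Cytotoxicity notes on a chain-shortened amide series

The compounds below may be only part of what the source reports. "The series", "measured", "known", "first", "only" and "open" are said of these compounds alone.

Three compounds of the series have so far been checked in an ADME assay on HEL cells (Homo sapiens) for cytotoxicity, read by microscopy, with a stated time of 6 days; on this read-out higher numbers stand for lower toxicity in this test and lower numbers for higher toxicity in this test. Compound 1, `CCCCCNc1cnc(C(=O)NCc2ccccc2)cn1`, returns only a limit of the assay: in this assay compound 1 gives > 100000 nM. Compound 2, `CCCCCCCNc1cnc(C(=O)NCc2ccccc2)cn1`, likewise stops at a limit: in this assay compound 2 gives > 100000 nM. Compound 3, `CCCCCCNc1cncc(C(=O)NCc2ccccc2)n1`, carries a different core, and the difference between the two cores is not broken down here. Compound 3 also returns a limit: in this assay compound 3 gives > 100000 nM.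

Within the data shown here, the one change traced between measured compounds is hydrogen in place of ethyl on a saturated chain carbon, five bonds along the chain from a nitrogen on an aromatic ring. The step that the two limits leave unreadable from compound 2 to compound 1 cannot be sized, because both compounds sit at the limit of > 100000 nM in this assay, at which 3 of the 3 values shown sit.

Compound 4, `CCCCNc1cncc(C(=O)NCc2ccccc2)n1`, is still to be measured. It differs from compound 3 by hydrogen in place of ethyl on a saturated chain carbon, four bonds along the chain from a nitrogen on an aromatic ring. Among the measured compounds shown here, this is the same kind of change as the one from compound 2 to compound 1, not the same: there the carbon is five bonds along the chain from a nitrogen on an aromatic ring, here it is four bonds along the chain from a nitrogen on an aromatic ring.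

The step to compound 4 is expected to be a number no higher from compound 3 to compound 4 (the limit leaves the size open), which rests on the whole measured set sitting at the limit of > 100000 nM in this assay, at which 3 of the 3 values shown sit. Compound 4 is accordingly estimated at 100000 nM, within a range from 50000 nM to 200000 nM, and most likely it will again report only a limit.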

Compound 4, minimum cytotoxic concentration: > 100000 nM
Compound 4 ended at the assay's limit; the forecaster's own chance of this, stated with the estimate: 85%; the middle value lies on the limit itself.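

No step from compound 3 to compound 4 can be read, because both compounds stop at a limit of the assay, as does the rest of the series: the limit of > 100000 nM in this assay, at which 4 of the 4 values shown sit.

The compounds shown leave open the actual minimum cytotoxic concentration of compound 1, compound 2, compound 3 and compound 4, and whether hydrogen in place of ethyl, or the difference between the two cores, changes it at all.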